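From a 4-Methylbenzyl to a 2-Bromobenzyl Triazole

This account rests on a few compounds, and the source may have more. Where it says the series, first, only, none or still open, it means among the compounds named here.

Measured compounds in a functional assay on QGY7701 cells (Homo sapiens) for cytotoxicity, read by MTT assay, with a stated time of 48 h; a higher number here means a weaker inhibitor, a lower number a stronger inhibitor:
compound 1 `Cc1cccc(Cn2cc(COc3ccc4c(=O)ccoc4c3)nn2)c1` gives 22400 nM
compound 2 `Cc1ccc(Cn2cc(COc3ccc4c(=O)ccoc4c3)nn2)cc1` gives 68500 nM
compound 3 `O=c1ccoc2cc(OCc3cn(Cc4ccccc4Cl)nn3)ccc12` gives 19700 nM

Compound 2 holds the highest of the three numbers in this assay. The step of a 3.1-fold higher number from compound 1 to compound 2 (0.49 log units; beyond the scatter) lifts it above compound 1, and the step of a 3.5-fold lower number from compound 2 to compound 3 (0.54 log units; beyond the scatter) brings it back down toward compound 3, both beyond the scatter, while the step of a 1.1-fold lower number from compound 1 to compound 3 (0.06 log units; within the scatter) leaves compound 1 and compound 3 within the scatter of each other. Compound 4 `O=c1ccoc2cc(OCc3cn(Cc4ccccc4Br)nn3)ccc12` has not yet been measured; it differs from compound 2 by 2-bromophenyl in place of 4-methylphenyl on a saturated chain carbon bound to an aromatic nitrogen. The closest measured step is a 3.5-fold lower number from compound 2 to compound 3 (0.54 log units; beyond the scatter), and a lowering of similar, modest size is therefore expected. The expected step is a 3.4-fold lower number from compound 2 to compound 4 (0.53 log units; beyond the scatter). For compound 4 in this assay a value of 20000 nM is estimated, with a range from 8000 nM to 50000 nM.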

Compound 4, half-maximal inhibitory concentration: > 100000 nM
Compound 4 was reported as a limit; the forecaster's own chance of this, stated with the estimate: 5%; at least 5.0-fold (0.69 log units) between middle value and limit.
By their numbers in this assay, from the lowest: compounds 3 and 1 (each within the scatter of the next); then compound 2. At a limit, above all of these: compound 4.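

In this assay compound 4 stands only as a limit: the limit of > 100000 nM in this assay, at which 1 of the 4 values shown sits. Bromo in place of chloro gives an at least 5.0-fold higher number from compound 3 to compound 4 (0.70 log units; beyond the scatter), the first sign that exchanging one halogen for another on this benzyl group can move the number beyond the scatter. The other steps differ: an at least 4.4-fold higher number from compound 1 to compound 4 (0.64 log units; beyond the scatter) also lies beyond the scatter, whereas an at least 1.4-fold higher number from compound 2 to compound 4 (0.16 log units; that floor lies within the scatter) has a floor within it, so the order of compound 2 and compound 4 remains less firmly set. The compounds shown leave open where a fluoro or a methoxy group in place of the bromo would fall.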